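The source may report more compounds than this note shows. Statements on the series, on what has been measured and on what is new or still open speak of the compounds shown alone.

Of the compounds shown here, two have so far been tested in a functional assay on SK-MEL-2 cells (Homo sapiens) for inhibition, read by sulforhodamine B assay, with a stated time of 48 h, tested at 10 uM; a higher number here means more inhibition of growth at the concentration tested, a lower number less inhibition of growth. Compound 1 `C/C(=N/O)c1ccc(NC(=O)Cn2nc(-c3ccccc3)nc2N)cc1` gives 5.32% in this assay, and compound 2 `c1ccc(-c2nc3sc(-c4ccccc4)cn3n2)cc1` gives 5%, the lower of the two numbers, although its gap to compound 1 lies within the scatter, so the two cannot be told apart. Compound 3 `COc1ccc(-c2nc3sc(-c4ccccc4)cn3n2)cc1` carries methoxy in place of hydrogen on an aromatic carbon. Going by the values given here, no measured pair shows the effect of such a change here, so the step expected from it, a number 3 percentage points higher from compound 2 to compound 3 (within the scatter), is small and has no direction beyond the scatter. Compound 3 is therefore estimated at 8%, with a likely range from -5% to 25%.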

Compound 3, percent growth inhibition at one concentration: 40%
For compound 3 the middle estimate is 32 percentage points below the measured one, and the stated range ends below it.
By their numbers in this assay, from the lowest: compounds 2 and 1 (each within the scatter of the next); then compound 3.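

The number in this assay shows a number 35 percentage points higher from compound 2 to compound 3 (beyond the scatter) when methoxy replaces hydrogen on an aromatic carbon, para to a large group. Going by these compounds alone, this is the first step between measured compounds, and it shows that this one small change on the shared core can move growth inhibition well beyond the scatter. Nothing available explains the rise.

A single pair cannot show whether the methoxy itself matters or whether another group here, such as an amine, a hydroxyl or a longer ethoxy chain, would do the same. On these data alone, how methoxy behaves on other carbons of the ring also remains open.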